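The source may hold more compounds than are shown below. What is called first, only, known or untested is meant among the compounds shown, and "the series" means these compounds.

Of the compounds shown here, three built on one shared core have been measured in an assay on CHO cells for displacement of a labelled ligand from D(4) dopamine receptor (Homo sapiens), read by radioligand binding; on this read-out higher numbers stand for weaker inhibition and lower numbers for stronger inhibition. Compound 1 `COc1ccccc1N1CCN(CCCNC(=O)NN(Cc2ccccc2F)c2ccc(F)cc2)CC1` gives 3.6 nM in this assay. Compound 2 `COc1ccccc1N1CCN(CCCNC(=O)NN(Cc2ccccc2F)c2ccc(Cl)cc2)CC1` gives 2.6 nM, and the step of a 1.4-fold lower number from compound 1 to compound 2 (0.14 log units; within the scatter) stays within the usual scatter. Compound 3 `COc1ccccc1N1CCN(CCCNC(=O)NN(Cc2ccccc2)c2ccc(Br)cc2)CC1` gives 3.4 nM; its number is the second highest of the three, yet it sits within the scatter of both compound 1 and compound 2.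

The next compound, compound 4 `COc1ccccc1N1CCN(CCCNC(=O)NN(Cc2ccccc2F)c2ccc(Br)cc2)CC1`, differs from compound 3 in one place: fluoro in place of hydrogen on an aromatic carbon. For the measured compounds named here, no measured pair shows this exact change. Going by the values given here, the only single-point step available, the halogen swap from compound 1 to compound 2, lies within the scatter, and compound 1 and compound 3, which differ in two places including this fluoro, give numbers within the scatter of each other. Nothing here points to a shift beyond the scatter, so the step of a 1.1-fold lower number from compound 3 to compound 4 (0.05 log units; within the scatter) is expected to be small. Compound 4 is therefore estimated at 3 nM, in a range from 1.5 nM to 6 nM, in this assay.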

Compound 4, inhibition constant: 3.3 nM
Beside the measured number, compound 4's estimate is 1.1-fold (0.04 log units) below it, and the stated range covers the measured number.
By their numbers in this assay, from the lowest: compounds 2, 4, 3 and 1 (each within the scatter of the next).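

Fluoro on this aromatic carbon, the change from benzyl to 2-fluorobenzyl, can now be read directly in this assay: with bromo held in place, a 1.0-fold lower number from compound 3 to compound 4 (0.01 log units; within the scatter) shows that this single atom leaves the number within the scatter. With the 2-fluorobenzyl group held in place, the halogen series of fluoro, chloro and bromo is now complete, and both new halogen steps, a 1.3-fold higher number from compound 2 to compound 4 (0.10 log units; within the scatter) and a 1.1-fold lower number from compound 1 to compound 4 (0.04 log units; within the scatter), also stay within the scatter. No evidence on why these steps are so small is available.

The compounds shown carry only hydrogen or fluoro at this benzyl position and only halogens as the other changing group, so the outcome with a methoxy group, an amine or a carboxylic acid at either place stays open. As far as these compounds go, how these compounds behave at any other receptor also stays open.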